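Trading 4-Fluorophenyl for Propyl on the Shared Core

The source may hold more compounds than are shown below. What is called first, only, known or untested is meant among the compounds shown, and "the series" means these compounds.

Three measured compounds share one core and differ only in the group on a saturated chain carbon bound to an oxygen on an aromatic ring. Compound 1 `O=C1CC(c2ccccc2OCc2ccc(F)cc2)Oc2ccccc21` carries 4-fluorophenyl there; in a functional assay on RAW264.7 cells (Mus musculus) for inhibition, read by Griess assay, with stated times of 1 h and 24 h (on this read-out higher numbers stand for weaker inhibition and lower numbers for stronger inhibition), compound 1 gives 28200 nM. Compound 2 `CC(C)CCOc1ccccc1C1CC(=O)c2ccccc2O1` gives 39200 nM and compound 3 `CC(C)COc1ccccc1C1CC(=O)c2ccccc2O1` gives 36700 nM. Compound 1 has the lowest of the three numbers, yet both steps away from it stay within the scatter: a 1.4-fold higher number from compound 1 to compound 2 (0.14 log units; within the scatter) and a 1.3-fold higher number from compound 1 to compound 3 (0.11 log units; within the scatter). Compound 4 `CCCCOc1ccccc1C1CC(=O)c2ccccc2O1` is not yet measured. propyl in place of 4-fluorophenyl on a saturated chain carbon bound to an oxygen on an aromatic ring The two measured steps that swapped 4-fluorophenyl for a saturated chain group barely moved the number, so in this assay the expected change is a 1.2-fold higher number from compound 1 to compound 4 (0.07 log units; within the scatter), nothing beyond the scatter. Compound 4 is therefore estimated at 33000 nM, ranging from 15000 nM to 70000 nM.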

Compound 4, half-maximal inhibitory concentration: 48700 nM
Compound 4: the middle estimate sits 1.5-fold (0.17 log units) below what was measured; measured number inside the range.
By their numbers in this assay, from the lowest: compounds 1, 3, 2 and 4 (each within the scatter of the next).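

Swapping 4-fluorophenyl for propyl gives the largest step seen so far at this position in this assay, yet it still stays within the scatter (a 1.7-fold higher number from compound 1 to compound 4 (0.24 log units; within the scatter)). The straight chain also stays level with the branched chains (a 1.3-fold higher number from compound 3 to compound 4 (0.12 log units; within the scatter); a 1.2-fold higher number from compound 2 to compound 4 (0.09 log units; within the scatter)), so neither the aromatic ring nor the branching separates these four compounds here. No measurement is at hand that could account for this flat result.

On these data alone, whether a longer chain would separate from these four remains open. So does whether an amine or a carboxylic acid at this place would move the number beyond the scatter.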